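An Amide Exchange on a Shared Core

A few compounds are considered here, and "the series" means these few. Any claim that something is new, unique, unknown or untested is made for them only; others in the source may bear on it.

compound 1 `Cc1cccc(C#Cc2nc3c(s2)C(=O)NCC3)c1`: > 10000 nM
compound 2 `O=C(C1CC1)N1CCc2nc(C#Cc3ccccc3)sc2C1`: > 10000 nM

In an assay on HEK293 cells for positive allosteric modulation of metabotropic glutamate receptor 5 (Homo sapiens), read by FLIPR, with a stated time of 1 h (on this read-out higher numbers stand for an effect only at larger amounts of compound and lower numbers for an effect already at smaller amounts), compound 1 gives only a limit, > 10000 nM. Compound 2 likewise gives only a limit, > 10000 nM. Both results fall at the limit of > 10000 nM in this assay, at which 2 of the 2 values shown sit, so nothing in the numbers places compound 2 above or below compound 1. Compound 3 `O=C(c1cccc(Cl)c1)N1CCc2nc(C#Cc3ccccc3)sc2C1` differs from compound 2 by 3-chlorophenyl in place of cyclopropyl on a carbonyl carbon. For the measured compounds named here, no step between measured compounds is available to guide the expectation; the step of an at least 1.2-fold lower number from compound 2 to compound 3 (0.09 log units; that floor lies within the scatter) is expected to be small, toward an effect at smaller amounts, with a fair chance that this assay again reports only a limit. Compound 3 is estimated at 8000 nM, within 2000 nM to 30000 nM.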

Compound 3, half-maximal effective concentration: 8.7 nM
Compound 3: the middle estimate sits 920-fold (2.96 log units) above what was measured, and the stated range ends above it.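

On this carbonyl carbon, whose other neighbour is the amide-type nitrogen in a ring, the choice of group proves decisive in this assay: 3-chlorophenyl in place of cyclopropyl gives an at least 1100-fold lower number from compound 2 to compound 3 (3.06 log units; beyond the scatter). The earlier compounds, both sitting at a limit, showed no measurable effect, so this position had not yet shown any response to change. Compound 2 gives only a limit, > 10000 nM, so this step has a floor but no known full size. The compounds shown leave open whether an unsubstituted phenyl or a 3-methoxyphenyl at this place would hold the effect, and thus whether the chlorine is needed at all.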